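A few compounds are considered here, and "the series" means these few. Any claim that something is new, unique, unknown or untested is made for them only; others in the source may bear on it.

Three thiosemicarbazones built on a shared core have been tested in a functional assay on 786-0 cells (Homo sapiens) for inhibition, read by sulforhodamine B assay, with a stated time of 48 h; a lower number here means a stronger inhibitor of growth, a higher number a weaker inhibitor of growth. Compound 1 `CC1=CC[C@H](C(C)(C)NC(=S)N/N=C/c2ccccc2Cl)CC1` gives 85500 nM. Compound 2 `CC1=CC[C@H](C(C)(C)NC(=S)N/N=C/c2cccc(Cl)c2)CC1` gives 9200 nM, and its core differs from that of compound 1 in one way: 3-chlorophenyl in place of 2-chlorophenyl on a carbon with a double bond to nitrogen. That change gave a 9.3-fold lower number from compound 1 to compound 2 (0.97 log units; beyond the scatter), so compound 2 stands with the lowest number of the three, its steps to the other two both lying beyond the scatter. Compound 3 `CC1=CC[C@H](C(C)(C)NC(=S)N/N=C/c2ccccc2[N+](=O)[O-])CC1` gives 68500 nM; it differs from compound 1 by nitro in place of chloro on an aromatic carbon, and this step was a 1.2-fold lower number from compound 1 to compound 3 (0.10 log units; within the scatter).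

Compound 4 `CC1=CC[C@H](C(C)(C)NC(=S)N/N=C/c2cccc([N+](=O)[O-])c2)CC1` has not yet been measured in this assay. It differs from compound 2 by nitro in place of chloro on an aromatic carbon. For the measured compounds named here, this is the same kind of change as the one from compound 1 to compound 3, but not the same: there the nitro sits ortho to a large group, here it sits meta to a large group. Going by the values given here, with only the one earlier example to go on, he expects the step from compound 2 to compound 4 to be about a 1.1-fold lower number from compound 2 to compound 4 (0.03 log units; within the scatter), resting on the fact that the earlier instance of this exchange was a 1.2-fold lower number from compound 1 to compound 3 (0.10 log units; within the scatter), which lies within the scatter. On that basis he estimates compound 4 at 8500 nM, with a likely range from 3000 nM to 25000 nM, noting that a single precedent on a differently placed group is a thin footing.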

Compound 4, concentration for 50% growth inhibition: > 100000 nM
Compound 4: no number, only a limit; the forecaster's own chance of this, stated with the estimate: 5%; middle value at least 11-fold (1.07 log units) away from the limit.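

In this assay, for the compounds shown here, compound 4 gives > 100000 nM, which is a limit of the assay and not a number, and it is the only compound at that limit: the limit of > 100000 nM in this assay, at which 1 of the 4 values shown sits. Even so, the exchange of chloro for nitro did not carry over from one core to the other, since the new step is an at least 10-fold higher number from compound 2 to compound 4 (1.03 log units; beyond the scatter), and the two instances of the change differ: the same change on two cores in this assay, a 1.2-fold lower number (0.10 log units; within the scatter) from compound 1 to compound 3 and an at least 10-fold higher number (1.03 log units; beyond the scatter) from compound 2 to compound 4, at least 13-fold (1.13 log units) apart, beyond the scatter of two such steps This shows that the near absence of change on the core of compound 1 cannot be assumed for the core of compound 2, but with one pair on each core and one end of the new step resting on a limit, it does not show the true size of that step, why the two instances part, or any rule for the wider series.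

The compounds shown carry only chloro and nitro on the aromatic ring, so they leave open how a bromo, a methoxy or a nitrile at those places would read in this assay. They also leave open whether a phenyl ring with neither chloro nor nitro would stand nearer to compound 2 or to compound 4.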